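From phenylsulfonyl to methyl at the assay limit

The source may report more compounds than this note shows. Statements on the series, on what has been measured and on what is new or still open speak of the compounds shown alone.

In a functional assay on P388 cells (Mus musculus) for inhibition (a higher number here means a weaker inhibitor, a lower number a stronger inhibitor), compound 1 (`Cc1ccc(/C=C\c2ccc3ccccc3c2)cc1`) gives > 5000 nM as a limit. Compound 2 (`O=S(=O)(c1ccccc1)n1ccc2cc(/C=C/c3ccc4ccccc4c3)ccc21`) gives > 5000 nM as a limit too. Compound 3 (`O=S(=O)(c1ccccc1)n1ccc2cc(/C=C\c3ccc4ccccc4c3)ccc21`) also gives only > 5000 nM as a limit, with no number of its own. Compound 4 (`Cn1ccc2cc(/C=C\c3ccc4ccccc4c3)ccc21`) has methyl in place of phenylsulfonyl on an aromatic nitrogen. Going by the values given here, the only measured step is a step that the two limits leave unreadable from compound 2 to compound 3 and it concerns another change, resting on the fact that compounds 2 and 3 differ only in the configuration as drawn and not on this one. With compound 3 given only as > 5000 nM as a limit, no size or direction can be read for the change, and none beyond the scatter is expected. The estimated outcome is a number no higher from compound 3 to compound 4 (the limit leaves the size open) in this assay for now. For compound 4 the expected value is 5000 nM with an estimated range from 1500 nM to 15000 nM as its bounds.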

Compound 4, half-maximal inhibitory concentration: > 5000 nM
Compound 4 ended at the assay's limit; the forecaster's own chance of this, stated with the estimate: 65%; the middle value sits exactly at the limit.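

Compound 3 and compound 4 both give only limits in this assay, and no new step can be read for methyl in place of phenylsulfonyl. The compounds shown leave open how strongly any of them inhibits, and whether this exchange matters at all.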